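The source may hold more compounds than are shown below. What is called first, only, known or untested is meant among the compounds shown, and "the series" means these compounds.

Compound 1 `C=C1C(=O)O[C@H]2CC3=C[C@H](C/C(C)=C/[C@@H](OC(=O)c4ccc(C(F)(F)F)cc4)[C@H]12)OC3=O`: > 10000 nM
Compound 2 `C=C1C(=O)O[C@H]2CC3=C[C@H](C/C(C)=C/[C@@H](OC(=O)c4ccc([N+](=O)[O-])cc4)[C@H]12)OC3=O`: > 10000 nM

In a functional assay on A549 cells (Homo sapiens) for cytotoxicity, read by MTT assay, with a stated time of 48 h (on this read-out lower numbers stand for stronger inhibition and higher numbers for weaker inhibition), compound 2 gives > 10000 nM, which is a limit and not a number. Both compounds sit at the limit of > 10000 nM in this assay, at which 2 of the 2 values shown sit. Compound 3 `C=C1C(=O)O[C@H]2CC3=C[C@H](C/C(C)=C/[C@@H](OC(=O)c4ccc(C(C)=O)cc4)[C@H]12)OC3=O` has acetyl in place of nitro on an aromatic carbon, (acetyl in place of nitro on an aromatic carbon). Among the measured compounds shown here, the only measured step bearing on this is a step that the two limits leave unreadable from compound 1 to compound 2, so it offers no size to carry over. No clear step in either direction is therefore expected, and compound 3 will probably stay weak in this assay. The expected step is a step that the limit leaves unreadable from compound 2 to compound 3. Compound 3 is estimated at 12000 nM, with an expected range of 5000 nM to 30000 nM.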

Compound 3, half-maximal inhibitory concentration: 2300 nM
Compound 3: the middle estimate sits 5.2-fold (0.72 log units) above what was measured; measured number outside the range, below it.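

In this assay, the group on this aromatic carbon proves able to move the read-out, which the first two compounds could not show. Acetyl in place of nitro gives an at least 4.3-fold lower number from compound 2 to compound 3 (0.63 log units; beyond the scatter), and acetyl in place of trifluoromethyl gives an at least 4.3-fold lower number from compound 1 to compound 3 (0.63 log units; beyond the scatter). Both sizes are only minimums, and the step between compound 1 and compound 2 cannot be read: the limit of > 10000 nM in this assay, at which 2 of the 3 values shown sit.

From the compounds shown here alone, whether the lower number depends on the carbonyl of acetyl or on the group as a whole stays open. So does how an amine, a carboxylic acid or a longer ketone chain would read at this place.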